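Acyl variation on the pyrrolidine amide of the sulfonamide series

The compounds below may be only part of what the source reports. "The series", "measured", "known", "first", "only" and "open" are said of these compounds alone.

Two members of the series have been measured in a functional assay on U2OS cells for antagonist activity at proto-oncogene Wnt-3 (Homo sapiens), read by a luciferase reporter, with a stated time of 18 h; on this read-out lower numbers stand for an effect already at smaller amounts and higher numbers for an effect only at larger amounts of compound. Compound 1 `CC(C)(C)OC(=O)N1CCC[C@H]1C(=O)N1CCC(NS(=O)(=O)c2cc(S(=O)(=O)c3ccccc3)ccc2C(F)(F)F)CC1` gives 60 nM in this assay, and compound 2 `O=C1CC[C@@H](C(=O)N2CCC(NS(=O)(=O)c3cc(S(=O)(=O)c4ccccc4)ccc3C(F)(F)F)CC2)N1` gives 240 nM. Going by the values given here, compound 2 therefore stands at the higher end of the two numbers; the single measured step, a 4.0-fold higher number from compound 1 to compound 2 (0.60 log units; beyond the scatter), separates it from compound 1.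

Compound 3 `CC(=O)N1CCC[C@H]1C(=O)N1CCC(NS(=O)(=O)c2cc(S(=O)(=O)c3ccccc3)ccc2C(F)(F)F)CC1` is the next point. Against compound 2 the change is 1-acetylpyrrolidin-2-yl in place of 5-oxopyrrolidin-2-yl on a carbonyl carbon. Compound 3 thus carries an acetyl group where compound 1 carries a tert-butoxycarbonyl group, and it gives up the lactam of compound 2. Among the compounds with values here, the only step that bears on this is a 4.0-fold higher number from compound 1 to compound 2 (0.60 log units; beyond the scatter), which moved from a 1-(tert-butoxycarbonyl)pyrrolidin-2-yl group to the 5-oxopyrrolidin-2-yl group; the present change reverses that direction with a smaller acyl group, so the bulk of that step is expected to be recovered, leaving compound 3 expected between compounds 1 and 2, nearer compound 1. The expected step is a 2.7-fold lower number from compound 2 to compound 3 (0.43 log units; beyond the scatter). Compound 3 is estimated at 90 nM in this assay, with a range from 40 nM to 250 nM.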

Compound 3, half-maximal effective concentration: 250 nM
Compound 3: the middle estimate sits 2.8-fold (0.44 log units) below what was measured, and the stated range covers the measured number.
By their numbers in this assay, from the lowest: compound 1; then compounds 2 and 3 (each within the scatter of the next).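

In this assay, the change from 5-oxopyrrolidin-2-yl to 1-acetylpyrrolidin-2-yl on this carbonyl carbon gives a 1.0-fold higher number from compound 2 to compound 3 (0.02 log units; within the scatter) and so leaves the number where the lactam had it. Methyl in place of tert-butoxy on a carbonyl carbon gives a 4.2-fold higher number from compound 1 to compound 3 (0.62 log units; beyond the scatter) in the same assay, which leaves compound 1 alone at the low end of the three. An acyl group on the pyrrolidine nitrogen is therefore not enough on its own to keep the lower number, since compound 3 has one, and among these three compounds that number goes only with the tert-butoxycarbonyl group. No data are at hand that bear on the reason for this difference.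

From the compounds shown here alone, whether the lower number needs the whole tert-butoxy group or also holds with a methoxy, ethoxy or isopropoxy group on the same carbonyl carbon remains open. Also open, going by these compounds, is how a pivaloyl group, which keeps the tert-butyl but lacks the ester oxygen, or a free pyrrolidine amine would compare with compound 1 here.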